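Adding chlorine to the sulfamoylphenyl arm of a pyrazolopyridine ketone

The compounds below may be only part of what the source reports. "The series", "measured", "known", "first", "only" and "open" are said of these compounds alone.

Of the compounds shown here, three sharing one core have been measured in an assay for binding affinity to dual specificity mitogen-activated protein kinase kinase 4 (Homo sapiens), read by KINOMEscan, tested at 100 nM; on this read-out higher numbers stand for a weaker effect at the one concentration tested and lower numbers for a stronger effect. Compound 1 `CCCS(=O)(=O)Nc1ccc(F)c(C(=O)c2n[nH]c3ncc(-c4cccc(OC)c4)cc23)c1F` gives 6.3%, compound 2 `CCCS(=O)(=O)Nc1ccc(F)c(C(=O)c2n[nH]c3ncc(-c4ccc(N(C)C)cc4)cc23)c1F` gives 2.5%, and compound 3 `CCCS(=O)(=O)Nc1ccc(F)c(C(=O)c2n[nH]c3ncc(-c4ccc(S(N)(=O)=O)cc4)cc23)c1F` gives 0.25%. Compound 2 stands second highest of the three, with compound 3 nearest and compound 1 furthest, and both gaps lie within the scatter, so the three cannot be ranked. Compound 4 `CCCS(=O)(=O)Nc1ccc(F)c(C(=O)c2n[nH]c3ncc(-c4ccc(S(N)(=O)=O)cc4Cl)cc23)c1F` is the new compound, differing from compound 2 in one place: 2-chloro-4-sulfamoylphenyl in place of 4-(dimethylamino)phenyl on an aromatic carbon. The closest measured step is a number 2.3 percentage points lower from compound 2 to compound 3 (within the scatter), where sulfamoyl replaced dimethylamino without the added chlorine; the steps of a number 3.8 percentage points lower from compound 1 to compound 2 (within the scatter) and a number 6.1 percentage points lower from compound 1 to compound 3 (within the scatter) also stayed within scatter. Going by the values given here, no measured pair shows what the chlorine alone does. Among the compounds with values here, since every step so far has stayed within the scatter, compound 4 is expected to stay low as well, with a step of a number 1.5 percentage points lower from compound 2 to compound 4 (within the scatter) that is not expected to exceed the scatter. The estimate for compound 4 in this assay is 1%, within a range from 0.1% to 8%.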

Compound 4, a percentage reported as activity, at one concentration (the size of the read-out at that concentration, not a potency): 3.4%
The estimate for compound 4 lay 2.4 percentage points below the measured number; the range from low to high includes it.
By their numbers in this assay, from the lowest: compounds 3, 2, 4 and 1 (each within the scatter of the next).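

In this assay, going by these compounds alone, the chloro group can be read on its own for the first time, as chloro in place of hydrogen gives a number 3.2 percentage points higher from compound 3 to compound 4 (within the scatter), so this single added atom makes no readable difference here. The whole-arm swaps agree, with a number 0.9 percentage points higher from compound 2 to compound 4 (within the scatter) and a number 2.9 percentage points lower from compound 1 to compound 4 (within the scatter), so the position has now carried 2-chloro-4-sulfamoylphenyl with no step beyond the scatter. Nothing available bears on how the arm or the chlorine acts in this result.

The four compounds all carry a phenyl arm at this position, so they leave open whether a morpholine or a carboxylic acid there would stay within the scatter. A single concentration also leaves open whether the chlorine would matter in a full potency measurement, or whether a methyl or a fluorine in its place would read the same.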